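Three Limit Values and a Morpholine Amide

The compounds below may be only part of what the source reports. "The series", "measured", "known", "first", "only" and "open" are said of these compounds alone.

Measured compounds with their values in a functional assay on MCF7 cells (Homo sapiens) for inhibition, read by sulforhodamine B assay, with a stated time of 72 h; on this read-out lower numbers stand for stronger inhibition of growth and higher numbers for weaker inhibition of growth:
compound 1 `O=C(O)/C=C/c1ccncc1-c1ccc2cc[nH]c2c1` — > 10000 nM
compound 2 `NC(=O)/C=C/c1ccncc1-c1ccc2ccccc2c1` — > 10000 nM
compound 3 `CNC(=O)/C=C/c1ccncc1-c1ccc2c(cnn2C)c1` — > 10000 nM.

For compound 2 the value > 10000 nM is a limit of the assay and not a measured number. Compound 2 therefore stands at the same limit as the other two compounds, and the evidence is simply (the limit of > 10000 nM in this assay, at which 3 of the 3 values shown sit). No comparison between any two of these compounds can be made beyond noting that all sit at the limit.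

Compound 4 `O=C(/C=C/c1ccncc1-c1ccc2ccccc2c1)N1CCOCC1` differs from compound 2 in one place: morpholin-4-yl in place of amino on a carbonyl carbon. Put more fully, a carbamoyl group becomes a (morpholin-4-yl)carbonyl group on the carbonyl carbon whose other neighbour is a double-bonded chain carbon.

For the measured compounds named here, no step between measured compounds exists to guide the expectation, and none of the three measured compounds gives a number at all. In this assay the expected step from compound 2 to compound 4 is none beyond the scatter, with compound 4 most likely again at the limit, so a step that the limit leaves unreadable from compound 2 to compound 4 is only a nominal figure. In this assay compound 4 is estimated at 15000 nM, with a range from 5000 nM to 50000 nM.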

Compound 4, concentration for 50% growth inhibition: > 10000 nM
Compound 4 gave a limit, no number; the forecaster's own chance of this, stated with the estimate: 80%; the middle value is on the limit's open side.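

In this assay compound 4 gives > 10000 nM, which is a limit of the assay and not a number. Compound 2 also stands at a limit, so no step can be read between compound 2 and compound 4, and the picture stays the same: the limit of > 10000 nM in this assay, at which 4 of the 4 values shown sit.

The compounds shown leave open whether swapping amino for morpholin-4-yl on the carbonyl carbon changes growth inhibition at all.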